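Replacing fluoro with tert-butyl in compound 3

A few compounds are considered here, and "the series" means these few. Any claim that something is new, unique, unknown or untested is made for them only; others in the source may bear on it.

In a functional assay on MDA-MB-231 cells (Homo sapiens) for antiproliferative activity, read by MTT assay, with a stated time of 72 h (on this read-out lower numbers stand for stronger inhibition and higher numbers for weaker inhibition), compound 1 (`CCNC(=O)CCc1cccc2c1B(O)OC2`) gives > 100000 nM, which is a limit of the assay. Compound 2 (`CC(C)(C)NC(=O)CCc1cccc2c1B(O)OC2`) gives > 100000 nM, also a limit. Going by the values given here, compound 3 (`O=C(CCc1cccc2c1B(O)OC2)Nc1ccc(F)cc1`) gives 440 nM, the only true number in the set. Two large steps lead to it, an at least 220-fold lower number from compound 1 to compound 3 (2.35 log units; beyond the scatter) and an at least 220-fold lower number from compound 2 to compound 3 (2.35 log units; beyond the scatter), and both install the 4-fluorophenyl on the amide-type nitrogen. Compound 4 (`CC(C)(C)c1ccc(NC(=O)CCc2cccc3c2B(O)OC3)cc1`) keeps that aromatic ring but has tert-butyl in place of fluoro on an aromatic carbon. Neither measured step changes that carbon, so they give no size for this change, and no shift beyond the scatter is expected in this assay. The expected change is a 1.4-fold higher number from compound 3 to compound 4 (0.13 log units; within the scatter). Compound 4 is estimated at 600 nM, within an expected range of 100 nM to 4000 nM.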

Compound 4, half-maximal inhibitory concentration: 33000 nM
Estimate against measurement, compound 4: 55-fold (1.74 log units) below; measured number above the stated range.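

In this assay, putting tert-butyl in place of fluoro on an aromatic carbon gives a 75-fold higher number from compound 3 to compound 4 (1.88 log units; beyond the scatter). Keeping the aromatic ring on the amide-type nitrogen is therefore not enough to hold the activity of compound 3, and the group on this carbon matters in its own right. Nothing shown here gives a cause for this loss. From the compounds shown here alone, only fluoro and tert-butyl appear on this carbon, so how a hydrogen, a methyl, a chloro or a methoxy group would read in this assay stays open.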